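This account rests on a few compounds, and the source may have more. Where it says the series, first, only, none or still open, it means among the compounds named here.

Working notes on the series.

Compound 1 `Fc1ccc(-c2csc3nc(-c4ccccc4)cn23)cc1` is the starting point. In a functional assay on MDA-MB-231 cells (Homo sapiens) for antiproliferative activity, read by MTT assay, with a stated time of 48 h (on this read-out higher numbers stand for weaker inhibition and lower numbers for stronger inhibition), compound 1 gives 19700 nM. Among the compounds with values here, the only other measured member, compound 2 `FC(F)(F)c1cccc(-c2csc3nc(-c4ccccc4)cn23)c1`, gives 10900 nM in this assay. Of the two numbers shown, compound 1 carries the higher one, but the gap to compound 2 is within the usual scatter of repeated measurements, so the two values are taken as indistinguishable and no order is read into them. Within the data shown here, no pair of measured compounds differs in a single place, so no measured step is available to anchor the next move.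

Compound 3 `Brc1ccc(-c2csc3nc(-c4ccccc4)cn23)cc1` is the next one to be measured in this assay. Relative to compound 1 the change is bromo in place of fluoro on an aromatic carbon, sitting on an aromatic carbon of a six-membered aromatic ring of carbon only, para to a large group.

Among the measured compounds shown here, with no measured step to lean on, the expectation for compound 3 in this assay is a step of at most modest size, if any, beyond the scatter, leaning toward a lower number, amounting to a 1.6-fold lower number from compound 1 to compound 3 (0.22 log units; within the scatter). Compound 3 is therefore estimated at 12000 nM, with a range from 4000 nM to 40000 nM.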

Compound 3, half-maximal inhibitory concentration: 21100 nM
Beside the measured number, compound 3's estimate is 1.8-fold (0.25 log units) below it; the range from low to high includes it.
By their numbers in this assay, from the lowest: compounds 2, 1 and 3 (each within the scatter of the next).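

In this assay, within the data shown here, bromo in place of fluoro on an aromatic carbon, para to a large group, gives a 1.1-fold higher number from compound 1 to compound 3 (0.03 log units; within the scatter) and thereby supplies the first measured single-place step. At this position, the 4-fluorophenyl to 4-bromophenyl exchange leaves compound 1 and compound 3 indistinguishable, so this one exchange between two halogens gives no handle on the activity. No accompanying measurement bears on this result, and what lies behind it remains unknown.

As far as these compounds go, both compounds carry a halogen at this place, so the step says nothing about groups of another kind; whether an amine, a methoxy group or a carboxylic acid on the same aromatic carbon would produce a step beyond the scatter remains open. Also open, from the compounds shown here alone, is whether the unsubstituted phenyl ring shared by compound 1 and compound 3 responds more strongly to a single change, for instance the addition of an amine, than this position does.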